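Ring nitrogen aryl swap: toward the pyrimidinyl analogue

The compounds below may be only part of what the source reports. "The series", "measured", "known", "first", "only" and "open" are said of these compounds alone.

Among the compounds with values here, compound 2 `N=C1S/C(=C\c2ccc(OCc3ccccc3)cc2)C(=O)N1c1ccccc1[N+](=O)[O-]` gives 24.4% in an ADME assay on RAW264.7 cells (Mus musculus) for cytotoxicity, read by MTT assay, with a stated time of 48 h, tested at 50 uM (a higher number here means more inhibition at the concentration tested (going by the name of the read-out), a lower number less inhibition), the higher of the two numbers measured so far; compound 1 `N=C1S/C(=C\c2ccc(OCc3ccccc3)cc2)C(=O)N1c1ccc(Br)cc1` gives 7.83%. Within the data shown here, the only measured step is a number 16.6 percentage points higher from compound 1 to compound 2 (beyond the scatter). Compound 3 `N=C1S/C(=C\c2ccc(OCc3ccccc3)cc2)C(=O)N1c1ncccn1` carries the change (pyrimidin-2-yl in place of 2-nitrophenyl on an amide-type nitrogen in a ring). That step bears on it because a number 16.6 percentage points higher from compound 1 to compound 2 (beyond the scatter) shows that swapping the group on this ring nitrogen can shift this assay by a modest amount, though it does not fix the direction for pyrimidin-2-yl. The expected step is a number 10.4 percentage points lower from compound 2 to compound 3 (beyond the scatter), modest and most likely downward. For compound 3 the estimate is 14%, range 0% to 30%.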

Compound 3, a percentage reported as inhibition, at one concentration (the size of the read-out at that concentration, not a potency): 26.6%
Compound 3: the middle estimate sits 12.6 percentage points below what was measured; the range from low to high includes it.
By their numbers in this assay, from the lowest: compound 1; then compounds 2 and 3 (each within the scatter of the next).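

On the amide-type nitrogen in a ring, this assay does not separate pyrimidin-2-yl from 2-nitrophenyl: the step is a number 2.2 percentage points higher from compound 2 to compound 3 (within the scatter) and so gives no order between them. Pyrimidin-2-yl in place of 4-bromophenyl gives a number 18.8 percentage points higher from compound 1 to compound 3 (beyond the scatter), which leaves compound 1 alone at the low end of the three. Nothing measured on hand accounts for this.

Open, going by these compounds, is whether an amine or a carboxylic acid on this nitrogen would read with compound 1 or with compound 2 and compound 3. Also open, on these data alone, is how a plain phenyl there would compare with 4-bromophenyl.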